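A few compounds are considered here, and "the series" means these few. Any claim that something is new, unique, unknown or untested is made for them only; others in the source may bear on it.

Three sulfonamides built on one shared core were tested in an assay on isolated protein for inhibition of malate dehydrogenase, mitochondrial (Sus scrofa), with stated times of 45 min and 30 min; on this read-out higher numbers stand for weaker inhibition and lower numbers for stronger inhibition. Compound 1, `COc1ccc(Cl)cc1S(=O)(=O)Nc1ccc(-c2nc3ccccc3o2)cc1`, carries a 5-chloro-2-methoxyphenyl on its sulfonyl sulfur. In this assay compound 1 gives > 63000 nM, which is a limit of the assay rather than a number. Compound 2, `O=S(=O)(Nc1ccc(-c2nc3ccccc3o2)cc1)c1ccc(C(F)(F)F)cc1`, gives > 63000 nM, again only a limit. Compound 3, `O=S(=O)(Nc1ccc(-c2nc3ccccc3o2)cc1)c1ccc(Cl)c(C(F)(F)F)c1`, gives > 63000 nM, also a limit. Compound 1 therefore stands level with its companions: all three values are described by the limit of > 63000 nM in this assay, at which 3 of the 3 values shown sit, and none of the three shows measurable inhibition.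

Compound 4, `O=S(=O)(Nc1ccc(-c2nc3ccccc3o2)cc1)c1cccc(O)c1`, has not yet been measured. It differs from compound 1 in one place: 3-hydroxyphenyl in place of 5-chloro-2-methoxyphenyl on a sulfonyl sulfur. Among the measured compounds shown here, nothing among the measured compounds shows that any change to the ring on the sulfonyl sulfur brings inhibition into the measurable range. The step that the limit leaves unreadable from compound 1 to compound 4 is thus expected to be none beyond the scatter. Compound 4 is estimated to give about 80000 nM, within 20000 nM to 300000 nM, and most likely to be reported only as a limit.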

Compound 4, half-maximal inhibitory concentration: > 63000 nM
Compound 4: no number, only a limit; the forecaster's own chance of this, stated with the estimate: 85%; the middle value is on the limit's open side.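

Among the compounds shown here, compound 4, like compound 1, gives only a limit in this assay, so no step between compound 1 and compound 4 can be read: the limit of > 63000 nM in this assay, at which 4 of the 4 values shown sit. The compounds shown leave open whether any ring on the sulfonyl sulfur of this shared core brings inhibition into the measurable range.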